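Fluoro for methyl on the sulfonyl aryl ring

This account rests on a few compounds, and the source may have more. Where it says the series, first, only, none or still open, it means among the compounds named here.

Compound 1 `Cc1ccc(S(=O)(=O)c2cnc3cc(F)ccc3c2-c2ccc(F)cc2)cc1C` gives 9.25 mL/min in an ADME assay on microsomes from liver (Homo sapiens) for metabolic stability, tested at 2.5 uM (a higher number here means faster removal of the compound, a lower number slower removal), the highest number of the three measured compounds. Compound 2 `COc1ccc(-c2c(S(=O)(=O)c3ccc(C)c(C)c3)cnc3cc(F)ccc23)cc1` gives 4.13 mL/min and compound 3 `Cc1ccc(S(=O)(=O)c2cnc3cc(F)ccc3c2-c2cccc(Cl)c2)cc1C` gives 4.01 mL/min. Both measured steps leave compound 1 downward: a 2.2-fold lower number from compound 1 to compound 2 (0.35 log units; beyond the scatter) and a 2.3-fold lower number from compound 1 to compound 3 (0.36 log units; beyond the scatter), each a modest change beyond the scatter, while compounds 2 and 3 sit within the scatter of each other, a 1.0-fold lower number from compound 2 to compound 3 (0.01 log units; within the scatter).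

Compound 4 `Cc1ccc(S(=O)(=O)c2cnc3cc(F)ccc3c2-c2ccc(F)cc2)cc1F` differs from compound 1 by fluoro in place of methyl on an aromatic carbon. Going by the values given here, both measured steps alter the aryl group on the core rather than the ring that carries the two methyl groups, so no measured step addresses this position directly. What the series shows is that single changes on either aryl group, when they moved the number, moved it modestly downward; a change of this size on the other ring is therefore expected to give at most a modest step, with a lower number somewhat more likely than a higher one, and a result within the scatter also plausible. Compound 4 is expected to give 6.5 mL/min in this assay, with a range of 3.5 mL/min to 11 mL/min, an estimated step of a 1.4-fold lower number from compound 1 to compound 4 (0.15 log units; within the scatter).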

Compound 4, intrinsic clearance in a liver preparation (reported as CLH), per the amount of preparation that the assay uses: 2.33 mL/min
The estimate for compound 4 lay 2.8-fold (0.45 log units) above the measured number; the measured number lies below the stated range.
By their numbers in this assay, from the lowest: compounds 4, 3 and 2 (each within the scatter of the next); then compound 1.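

Going by these compounds alone, the ring that carries the two methyl groups, untouched by the earlier steps, also moves the number: in this assay, 3,4-dimethylphenyl to 3-fluoro-4-methylphenyl gives a 4.0-fold lower number from compound 1 to compound 4 (0.60 log units; beyond the scatter). A single-atom exchange on this ring is therefore enough for a step beyond the scatter, in the same downward direction as the changes on the other aryl group, a 2.2-fold lower number from compound 1 to compound 2 (0.35 log units; beyond the scatter) and a 2.3-fold lower number from compound 1 to compound 3 (0.36 log units; beyond the scatter). Nothing available explains why this exchange lowers the number.

Still open, from the compounds shown here alone, is whether a nitrile, an amine or a chloro in the same place would move the number in the same way. Also open, going by these compounds, is whether this exchange gives a similar step with 3-chlorophenyl or 4-methoxyphenyl in place of the 4-fluorophenyl group on the shared core.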